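Replacing a branched fluoroalkyl arm on a weak agonist

The source may hold more compounds than are shown below. What is called first, only, known or untested is meant among the compounds shown, and "the series" means these compounds.

The series is read in an assay on isolated protein for agonist activity at prostaglandin E2 receptor EP4 subtype (Homo sapiens); a higher number here means that more compound is needed for the effect, a lower number that less compound is needed. Compound 1 `CCCCC(C)(C)[C@H](O)/C=C/[C@H]1CCC(=O)N1CCSc1nc(C(=O)O)cs1` gives 4.2 nM in this assay. Compound 2 `CC(C)(CCCCF)[C@H](O)/C=C/[C@H]1COC(=O)N1CCSc1nc(C(=O)O)cs1`, which carries a different core, gives 1220 nM in this assay, the highest of the two numbers; the two compounds differ in more than one place, so the gap between them is reported here only as what the two values show. Compound 3 `COCCCC1([C@H](O)/C=C/[C@H]2COC(=O)N2CCSc2nc(C(=O)O)cs2)CCC1` keeps the core of compound 2 and differs from it in one place: 1-(3-methoxypropyl)cyclobutyl in place of 5-fluoro-1,1-dimethylpentyl on a saturated chain carbon bound to a double-bonded chain carbon and an oxygen on a saturated carbon. For the measured compounds named here, no pair of measured compounds shares this change, so no measured step is available to set its size. With compound 2 as the only anchor on this core, the step is estimated as a modest lowering of the number, from compound 2 to compound 3 a 2.0-fold lower number from compound 2 to compound 3 (0.31 log units; beyond the scatter), with a wide band that also admits no change beyond the scatter. Compound 3 is therefore expected to give about 600 nM in this assay, within a range from 100 nM to 3500 nM.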

Compound 3, half-maximal effective concentration: 705 nM
Estimate against measurement, compound 3: 1.2-fold (0.07 log units) below; the range from low to high includes it.
By their numbers in this assay, from the lowest: compound 1; then compounds 3 and 2 (each within the scatter of the next).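

Placing 1-(3-methoxypropyl)cyclobutyl in place of 5-fluoro-1,1-dimethylpentyl on a saturated chain carbon bound to a double-bonded chain carbon and an oxygen on a saturated carbon gives, in this assay, a 1.7-fold lower number from compound 2 to compound 3 (0.24 log units; within the scatter) and so leaves the two arms indistinguishable in this read-out. For the compounds shown here, this is the first measured step at this position, and it shows that on the core of compound 2 the arm can take on a four-membered carbon ring and an ether oxygen, and lose its fluorine, with no change beyond the scatter. Nothing at hand explains this outcome or assigns a share of it to any one of these differences.

Going by these compounds, both arms sit on the same core, so it remains open whether the exchange would read the same on the core of compound 1, which gives 4.2 nM and differs from compound 2 in more than one place. Also open, on these data alone, is how the number would respond at this position to a cyclopentyl ring in place of the cyclobutyl ring, or to an amine in place of the methoxy group at the end of the arm.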